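Dropping a methyl from a thiocarbamate: expected effect on cytotoxicity

The source may hold more compounds than are shown below. What is called first, only, known or untested is meant among the compounds shown, and "the series" means these compounds.

Measured compounds:
Compound 1, `Cc1ccc(NC(=S)OCCNC(=O)C(C)(C)Oc2ccc(Cl)cc2)cc1`: 661000 nM
Compound 2, `O=C(NCCOC(=S)Nc1ccccc1)c1cccnc1`: 724000 nM
Compound 3, `NC(=S)c1ccc(OC(=O)c2cccnc2)cc1`: 683000 nM

Of the compounds shown here, three have been tested in an ADME assay on HUVEC cells (Homo sapiens) for cytotoxicity, read by MTT assay, with a stated time of 48 h; a higher number here means a weaker inhibitor, a lower number a stronger inhibitor. Compound 1 gives 661000 nM in this assay, the smallest number of the three, but its gap to compound 3 at 683000 nM and to compound 2 at 724000 nM both lie within the usual scatter of repeated measurements, so on these numbers the three compounds cannot be told apart; all three are weak inhibitors of HUVEC cell viability.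

Compound 4, `CC(C)(Oc1ccc(Cl)cc1)C(=O)NCCOC(=S)Nc1ccccc1`, has not yet been measured. It is compound 1 with one change: hydrogen in place of methyl on an aromatic carbon. Going by the values given here, no step between two measured compounds shows what such a change does in this assay, and the three measured compounds, which differ in many places at once, all give near-identical numbers. The change itself is small, a single carbon atom leaving. The expectation is therefore a step of no real size, none beyond the scatter: the estimated step of a 1.0-fold higher number from compound 1 to compound 4 (0.01 log units; within the scatter) is close to flat. Compound 4 is expected to give about 680000 nM in this assay, with a plausible range from 380000 nM to 1200000 nM.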

Compound 4, half-maximal inhibitory concentration: 791000 nM
Estimate against measurement, compound 4: 1.2-fold (0.07 log units) below; low and high end bracket the measured number.
By their numbers in this assay, from the lowest: compounds 1, 3, 2 and 4 (each within the scatter of the next).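

In this assay, going by these compounds alone, going from 4-methylphenyl to phenyl gives a 1.2-fold higher number from compound 1 to compound 4 (0.08 log units; within the scatter), the first reading of a single change in these compounds. The three earlier compounds differ in many places at once, so their close numbers could not show what any one group does. This pair isolates the methyl on the aromatic carbon, para to a large group, and removing it leaves a step that cannot be told apart from repeat-measurement noise, so in this assay hydrogen and methyl are not distinguishable at this position on the core of compound 1. No measurement available here offers an explanation for this flat step.

The compounds shown leave open whether a different group at the same position, such as an amine, a carboxylic acid or a longer alkyl chain, would move the number beyond the scatter. They also leave open whether the same swap of methyl for hydrogen would stay as flat on another core, as one pair speaks for a single setting only.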